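Moving the amino group on compound 3

The source may hold more compounds than are shown below. What is called first, only, known or untested is meant among the compounds shown, and "the series" means these compounds.

Compound 3 `Cc1ccc(CN2C(=O)S/C(=C\c3ccc(N)cc3)C2=O)cc1` gives the lowest number of the three measured in a functional assay on L1210 cells (Mus musculus) for cytotoxicity, read by cell counting, with a stated time of 2 days (on this read-out higher numbers stand for weaker inhibition and lower numbers for stronger inhibition), at 94000 nM; compound 1 `Nc1cccc(/C=C2\SC(=O)N(Cc3cccc(F)c3)C2=O)c1` gives 199000 nM and compound 2 `Nc1cccc(/C=C2\SC(=O)N(Cc3cccc(Cl)c3)C2=O)c1` gives 211000 nM, both beyond the scatter from compound 3. Within the data shown here, the only measured step, a 1.1-fold higher number from compound 1 to compound 2 (0.03 log units; within the scatter), concerns the benzyl substituent and does not bear on the change to compound 4 `Cc1ccc(CN2C(=O)S/C(=C\c3cccc(N)c3)C2=O)cc1`: 3-aminophenyl in place of 4-aminophenyl on a double-bonded chain carbon bound to a double-bonded ring carbon. Compound 1 and compound 2 carry the 3-aminophenyl alongside halogen benzyl groups, a different pairing, so their values are only a loose guide. Compound 4 is expected to give a higher number than compound 3, a step of about a 1.6-fold higher number from compound 3 to compound 4 (0.20 log units; within the scatter), with wide uncertainty. The estimate for compound 4 in this assay is 150000 nM, range 70000 nM to 320000 nM.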

Compound 4, half-maximal inhibitory concentration: 176000 nM
Compound 4: the middle estimate sits 1.2-fold (0.07 log units) below what was measured, and the stated range covers the measured number.
By their numbers in this assay, from the lowest: compounds 3, 4, 1 and 2 (each within the scatter of the next, the first and the last beyond it).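

Moving the amino group gives a 1.9-fold higher number from compound 3 to compound 4 (0.27 log units; within the scatter) in this assay, so 3-aminophenyl in place of 4-aminophenyl at this position gives a step within the scatter. With 3-aminophenyl held fixed, 4-methylphenyl on the saturated chain carbon also stays within the scatter of the halogen groups, with a 1.2-fold lower number from compound 2 to compound 4 (0.08 log units; within the scatter) and a 1.1-fold lower number from compound 1 to compound 4 (0.05 log units; within the scatter) on that side. Nothing available explains these results.

On these data alone, it remains open whether a hydroxyl or a carboxylic acid in place of the amino group would shift the number beyond the scatter. The same question stands for a longer chain in place of the benzyl link.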